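This account rests on a few compounds, and the source may have more. Where it says the series, first, only, none or still open, it means among the compounds named here.

Series notes. The shared core is that of compound 1 `CCc1cc(/C=C/C(=O)c2ccccc2NC(=O)NS(=O)(=O)c2ccc(C)cc2)cc(OC)c1OC`; the three measured compounds differ only in the aryl group on a double-bonded chain carbon bound to a double-bonded chain carbon. In an ADME assay on the whole organism for cytotoxicity, with Artemia salina as the target, with a stated time of 24 h (a lower number here means that less compound is needed, a higher number that more compound is needed for the effect), compound 1 gives 19.2 ug/mL, the second highest of the three numbers in hand. Compound 2 `Cc1ccc(S(=O)(=O)NC(=O)Nc2ccccc2C(=O)/C=C/c2ccccc2[N+](=O)[O-])cc1` gives 40.1 ug/mL in this assay, and compound 3 `Cc1ccc(S(=O)(=O)NC(=O)Nc2ccccc2C(=O)/C=C/c2cccc(F)c2)cc1` gives 4.13 ug/mL. The steps are a 2.1-fold higher number from compound 1 to compound 2 (0.32 log units; beyond the scatter), a 4.6-fold lower number from compound 1 to compound 3 (0.67 log units; beyond the scatter) and a 9.7-fold lower number from compound 2 to compound 3 (0.99 log units; beyond the scatter), all beyond the scatter.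

Compound 4 `Cc1ccc(S(=O)(=O)NC(=O)Nc2ccccc2C(=O)/C=C/c2ccccc2Cl)cc1` is not yet measured. Its change from compound 1 is 2-chlorophenyl in place of 3-ethyl-4,5-dimethoxyphenyl on a double-bonded chain carbon bound to a double-bonded chain carbon. Both measured steps from compound 1 bear on it, as each also swaps the 3-ethyl-4,5-dimethoxyphenyl for a substituted phenyl, but they point opposite ways: 3-fluorophenyl brought the number down, 2-nitrophenyl pushed it up. The entering 2-chlorophenyl resembles the group of compound 3 in carrying a halogen and resembles the group of compound 2 in the naming of its substituent. The expected step of a 1.9-fold lower number from compound 1 to compound 4 (0.28 log units; within the scatter) is therefore a lower number, beyond the scatter but smaller than the step to compound 3. Compound 4 is estimated at 10 ug/mL, with a range of 4 ug/mL to 28 ug/mL.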

Compound 4, concentration for half-maximal effect: 12.8 ug/mL
For compound 4 the middle estimate is 1.3-fold (0.11 log units) below the measured one, within the range that was stated.
By their numbers in this assay, from the lowest: compound 3; then compounds 4 and 1 (each within the scatter of the next); then compound 2.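

In this assay, 2-chlorophenyl in place of 3-ethyl-4,5-dimethoxyphenyl gives a 1.5-fold lower number from compound 1 to compound 4 (0.18 log units; within the scatter) and so does not separate the two groups, even though the entering group has fewer heavy atoms and no hydrogen-bond acceptors; at this position, those counts alone do not fix the number. The nitro and chloro pair gives the series its first change of a single substituent on an otherwise identical phenyl group, and a 3.1-fold lower number from compound 2 to compound 4 (0.50 log units; beyond the scatter) stands beyond the scatter, showing that chloro in place of nitro on an aromatic carbon is enough to move the number. Carrying a halogen does not by itself bring a compound to the level of compound 3: 2-chlorophenyl in place of 3-fluorophenyl gives a 3.1-fold higher number from compound 3 to compound 4 (0.49 log units; beyond the scatter) as a step beyond the scatter, although that change alters both the halogen and the group's substitution pattern, and these two cannot be parted here.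

On these data alone, how an amine or a carboxylic acid in place of the chloro would read remains open. Nothing at hand gives a reason for any of these steps.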